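This account rests on a few compounds, and the source may have more. Where it says the series, first, only, none or still open, it means among the compounds named here.

Measured in an ADME assay on MDBK cells (Bos taurus) for cytotoxicity, read by MTT assay, with a stated time of 72 h; on this read-out lower numbers stand for higher toxicity in this test and higher numbers for lower toxicity in this test:
Compound 1 `FC(F)(F)c1ccc(NCc2cn(-c3ccccc3)nc2-c2ccc(Br)cc2)cc1`: 46000 nM
Compound 2 `Cc1ccc(-c2nn(-c3ccccc3)cc2CNc2ccc(Br)cc2)cc1`: > 100000 nM

Compound 2 gives no number here, only a limit, > 100000 nM. On these data alone, its true position in this assay therefore remains open, and any comparison starting from it is rough.

Compound 3 `Brc1ccc(NCc2cn(-c3ccccc3)nc2-c2ccc(Br)cc2)cc1` differs from compound 2 in one place: bromo in place of methyl on an aromatic carbon. This puts bromo in place of methyl on an aromatic carbon, so 4-methylphenyl becomes 4-bromophenyl.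

Among the measured compounds shown here, the same 4-bromophenyl is present in compound 1, which gives 46000 nM, the only true number so far. Compound 3 is therefore expected to read lower than the limit, though another reading at the limit remains possible. The expected change, an at least 1.6-fold lower number from compound 2 to compound 3 (0.22 log units; that floor lies within the scatter), is modest and points towards higher toxicity in this test. For compound 3 the estimated value is 60000 nM, with an expected range of 28000 nM to 100000 nM.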

Compound 3, half-maximal cytotoxic concentration: > 100000 nM
Compound 3: no number, only a limit (the forecaster's own chance of this, stated with the estimate: 35%); middle value at least 1.6-fold (0.22 log units) from the limit.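

Compound 3 gives only a limit in this assay, > 100000 nM. The change from 4-methylphenyl to 4-bromophenyl therefore cannot be read, because the values of compound 2 and compound 3 both stop at the same limit: the limit of > 100000 nM in this assay, at which 2 of the 3 values shown sit.

The new compound does give one readable comparison, at a different place in the molecule, where bromo stands in place of trifluoromethyl: an at least 2.1-fold higher number from compound 1 to compound 3 (0.33 log units; beyond the scatter). So, of these two compounds, the one with trifluoromethyl shows the higher toxicity in this test.

On these data alone, how far 4-methylphenyl and 4-bromophenyl truly differ stays open, since neither has a number here. Also open, as far as these compounds go, is whether an amine or a carboxylic acid in place of bromo on 4-bromophenyl would bring a reading below the limit.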